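The compounds below may be only part of what the source reports. "The series", "measured", "known", "first", "only" and "open" are said of these compounds alone.

Values in a functional assay on SK-OV-3 cells (Homo sapiens) for antiproliferative activity, read by MTT assay, with a stated time of 72 h; on this read-out lower numbers stand for stronger inhibition and higher numbers for weaker inhibition:
- Compound 1 `O=C(Nc1ccccn1)c1cc(=O)[nH]c2cc(Br)ccc12`: > 20000 nM (a limit)
- Compound 2 `O=C(Nc1cccc(F)c1)c1cc(=O)[nH]c2cc(Br)ccc12`: 10600 nM
- Compound 3 `O=C(Nc1cc(F)cc(F)c1)c1cc(=O)[nH]c2cc(Br)ccc12`: 10800 nM

Among the measured compounds shown here, compound 2 gives 10600 nM and sits level with compound 3 within the scatter, and these are the only two true numbers in the set. The value of compound 1 is a limit.

Next is compound 4 `O=C(Nc1cccc(F)c1)c1cc(=O)[nH]c2cc(-c3ccc(F)cc3)ccc12`, with 4-fluorophenyl in place of bromo on an aromatic carbon. Both measured steps lie on the amide side and leave the bromo in place. The first is an at least 1.8-fold lower number from compound 1 to compound 2 (0.27 log units; that floor lies within the scatter), and the second is a 1.0-fold higher number from compound 2 to compound 3 (0.01 log units; within the scatter). For the measured compounds named here, neither therefore gives a size for this change, and no measured compound varies at this place. In this assay a moderate move towards a lower number is tentatively expected, resting only on the size of the change, and a result with no shift beyond the scatter remains possible. The expected change is a 2.1-fold lower number from compound 2 to compound 4 (0.33 log units; beyond the scatter). For compound 4 the estimated value is 5000 nM, with an expected range of 1000 nM to 20000 nM.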

Compound 4, half-maximal inhibitory concentration: 16600 nM
Compound 4: the middle estimate sits 3.3-fold (0.52 log units) below what was measured; the measured number falls inside the stated range.
By their numbers in this assay, from the lowest: compounds 2, 3 and 4 (each within the scatter of the next). At a limit, above all of these: compound 1.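

In this assay, among the compounds shown here, the first change at this aromatic carbon of the fused system gives a 1.6-fold higher number from compound 2 to compound 4 (0.19 log units; within the scatter), so replacing bromo with 4-fluorophenyl produces no shift beyond the scatter. This position therefore accepts a single bromine giving way to a group of seven heavy atoms carrying a six-membered aromatic ring, with the amide side held constant, and the added ring brings no measurable gain in inhibition over bromo. The readings of the series still lie close to the upper end of the read-out, where one compound already stands at a limit: the limit of > 20000 nM in this assay, at which 1 of the 4 values shown sits.

Going by these compounds, whether an amine, a carboxylic acid or a morpholine at this carbon would move the number beyond the scatter remains open. Also open, on these data alone, is whether 4-fluorophenyl gives the same reading when paired with the amide side of compound 1 or compound 3.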